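Amino for Methyl on Two Related Cores

A few compounds are considered here, and "the series" means these few. Any claim that something is new, unique, unknown or untested is made for them only; others in the source may bear on it.

Measured compounds:
Compound 1, `Cc1noc(C2CN3CCN2CC3)n1`: 6
Compound 2, `Nc1noc(C2CN3CCN2CC3)n1`: 6.3
Compound 3, `Cc1noc(C2CN(C)CCN2)n1`: 6.2

Of the compounds shown here, three have been measured in a physicochemical assay for acid dissociation. Compound 1 `Cc1noc(C2CN3CCN2CC3)n1` gives 6 in this assay. Compound 2 `Nc1noc(C2CN3CCN2CC3)n1` gives 6.3. The change between them, (amino in place of methyl on an aromatic carbon), moves the value by a number 0.30 log units higher from compound 1 to compound 2 (within the scatter). Compound 3 `Cc1noc(C2CN(C)CCN2)n1` gives 6.2, which lies within the scatter of both compound 1 and compound 2; the difference between the core of compound 3 and the core of compound 1 is not broken down here.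

Compound 4 `CN1CCNC(c2nc(N)no2)C1` has not yet been measured. It differs from compound 3 by amino in place of methyl on an aromatic carbon. This is the same kind of change as that from compound 1 to compound 2; the two places differ only in that the ring atom two ring bonds away bears a group of 7 heavy atoms in compound 3 and a group of 8 heavy atoms in compound 1. Since the same kind of change gave a number 0.30 log units higher from compound 1 to compound 2 (within the scatter), the step from compound 3 to compound 4 in this assay is expected to be about a number 0.30 log units higher from compound 3 to compound 4 (within the scatter), also within the scatter. Compound 4 is therefore estimated at 6.5, with a range from 6.1 to 6.9.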

Compound 4, acid dissociation constant: 6.2
Beside the measured number, compound 4's estimate is 0.30 log units above it, and the stated range covers the measured number.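

Carried onto the core of compound 3, amino in place of methyl on an aromatic carbon gives, in this assay, no change at the digits printed from compound 3 to compound 4 (within the scatter), while on the core of compound 1 the same change gave a number 0.30 log units higher from compound 1 to compound 2 (within the scatter) as its step. Both steps lie within the usual scatter, so neither pair shows a readable effect of the change on this read-out, and the two results agree only in that sense: the change can be made on either core without a step that stands clear of repeat measurement, but these two pairs do not show that the cores respond differently or that they respond alike at a finer level. No information that bears on the result is at hand to account for it.

The compounds shown leave open whether any other group on that same aromatic carbon, such as a carboxylic acid, a methoxy group or a longer chain, would give a step beyond the scatter on either core. They also leave open whether a step of that kind, once seen on one core, would carry over to the other.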